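Trading 1H-benzimidazol-5-yl for 1H-indazol-6-yl: one open question

A few compounds are considered here, and "the series" means these few. Any claim that something is new, unique, unknown or untested is made for them only; others in the source may bear on it.

- compound 1 `CC/C(=C(/c1ccc(/C=C/C(=O)O)cc1)c1ccc(O)nc1)c1ccccc1`: "not determined" (no result reported)
- compound 2 `CC/C(=C(/c1ccc(/C=C/C(=O)O)cc1)c1ccc2[nH]cnc2c1)c1ccccc1`: 1180 nM

In a functional assay on MCF7 cells (Homo sapiens) for cytotoxicity, read by CellTiter-Glo, with a stated time of 5 days (on this read-out higher numbers stand for weaker inhibition and lower numbers for stronger inhibition), compound 2 gives 1180 nM. Among the measured compounds shown here, this is the only number available, and compound 1 has no result to compare it with. Compound 2 therefore cannot yet be ranked against a relative.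

The next compound, compound 3 `CC/C(=C(/c1ccc(/C=C/C(=O)O)cc1)c1ccc2cn[nH]c2c1)c1ccccc1`, differs from compound 2 in one place: 1H-indazol-6-yl in place of 1H-benzimidazol-5-yl on a double-bonded chain carbon bound to an aromatic carbon and a double-bonded chain carbon. The 1H-indazol-6-yl group sits on a double-bonded chain carbon bound to an aromatic carbon and a double-bonded chain carbon. The two groups have the same atoms, joined differently.

For the measured compounds named here, no measured pair shows how much such a swap matters in this assay. The starting point for the expectation is therefore compound 2 at 1180 nM, with no clear direction of change. The expected result is a step of a 1.1-fold lower number from compound 2 to compound 3 (0.03 log units; within the scatter), within the usual scatter. Compound 3 is estimated at 1100 nM, with an expected range of 350 nM to 3500 nM.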

Compound 3, half-maximal inhibitory concentration: 570 nM
Estimate against measurement, compound 3: 1.9-fold (0.29 log units) above; measured number inside the range.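

In this assay, trading 1H-benzimidazol-5-yl for 1H-indazol-6-yl gives a 2.1-fold lower number from compound 2 to compound 3 (0.32 log units; beyond the scatter), a modest change but one that lies beyond the usual scatter. This place on the molecule therefore responds to how the atoms of the group are joined, since both groups match in heavy atoms, rings, hydrogen-bond donors and hydrogen-bond acceptors. Nothing available explains why this rearrangement lowers the number.

Among the compounds shown here, compound 1 has no result, so no step involving it can be read, and the group it carries at this place remains unranked against the other two. Also open, as far as these compounds go, is whether an indolyl or aminophenyl group at this place would continue the gain seen with 1H-indazol-6-yl or lose it, since a single swap gives no trend.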